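The source may report more compounds than this note shows. Statements on the series, on what has been measured and on what is new or still open speak of the compounds shown alone.

Measured so far in a functional assay on NB-4 cells (Homo sapiens) for cytotoxicity, read by CCK-8 assay, with a stated time of 24 h; on this read-out higher numbers stand for weaker inhibition and lower numbers for stronger inhibition:
- compound 1 `C=CC(=O)N1C(=O)CC(C)Sc2ccccc21`: 227000 nM
- compound 2 `C=CC(=O)N1C(=O)CC(c2ccc(-c3ccccc3)cc2)Sc2ccccc21`: 57700 nM

Only these two compounds have numbers in this assay. Compound 2 holds the lower number at 57700 nM, and compound 1 stands higher at 227000 nM, a gap that lies beyond the usual scatter. Both numbers are high, so neither compound is a strong inhibitor on this read-out.

The next compound is compound 3 `C=CC(=O)N1C(=O)CC(c2ccccc2)Sc2ccccc21`, which has hydrogen in place of phenyl on an aromatic carbon. Within the data shown here, no measured pair differs in one place only, so no direct precedent exists for this change, and the expectation rests on the two values alone. Compound 3 is expected to fall between compound 2 at 57700 nM and compound 1 at 227000 nM, which would mean a moderate move towards weaker inhibition in this assay. The estimated step is a 1.9-fold higher number from compound 2 to compound 3 (0.28 log units; within the scatter), and it may not clear the scatter by much. For compound 3 the expected value is 110000 nM, with an estimated range from 50000 nM to 250000 nM.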

Compound 3, half-maximal inhibitory concentration: 35500 nM
Beside the measured number, compound 3's estimate is 3.1-fold (0.49 log units) above it; measured number below the stated range.
By their numbers in this assay, from the lowest: compounds 3 and 2 (each within the scatter of the next); then compound 1.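

In this assay the exchange of hydrogen for phenyl on an aromatic carbon, para to a large group, gives a 1.6-fold lower number from compound 2 to compound 3 (0.21 log units; within the scatter) and so this read-out does not separate the two groups at this position. The new comparison on the saturated ring carbon, phenyl in place of methyl, gives a 6.4-fold lower number from compound 1 to compound 3 (0.81 log units; beyond the scatter) and is the only step shown that lies beyond the scatter, which places the one clear difference among these one-place pairs at that carbon and not on the outer aromatic position. No measurement is available that bears on the origin of either step.

On these data alone, it remains open whether a different group on that aromatic carbon, such as a methoxy group, an amine or a carboxylic acid, would give a step beyond the scatter where phenyl and hydrogen do not. The compounds shown also leave open how an ethyl group, a longer chain or a pyridine ring on the saturated ring carbon would compare with methyl and phenyl there.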